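A few compounds are considered here, and "the series" means these few. Any claim that something is new, unique, unknown or untested is made for them only; others in the source may bear on it.

Measured so far, in a functional assay on PC-3M cells (Homo sapiens) for cytotoxicity, read by MTT assay, with a stated time of 48 h; on this read-out higher numbers stand for weaker inhibition and lower numbers for stronger inhibition:
Compound 1 `CCCc1nnc(SCC(=O)c2ccc(Cl)cc2)n1N1C(=O)c2ccccc2C1=O` gives only a limit of the assay, > 200000 nM.
Compound 2 `COc1cc(-c2nnc(SCc3ccccc3Cl)n2N2C(=O)c3ccccc3C2=O)cc(OC)c1OC` gives only a limit, > 200000 nM.
Compound 3 `C#CCSc1nnc(-c2cc(OC)c(OC)c(OC)c2)n1N1C(=O)c2ccccc2C1=O` gives only a limit, > 200000 nM.

Compound 3 therefore cannot be placed in any order among these three; all that is known is that it sits at the limit, as the others do. Among the measured compounds shown here, the one measured step at the same place, a step that the two limits leave unreadable from compound 2 to compound 3, has a size that cannot be read, because of the limit of > 200000 nM in this assay, at which 3 of the 3 values shown sit. Compound 4 `COc1cc(-c2nnc(SCC(=O)c3ccc(Cl)cc3)n2N2C(=O)c3ccccc3C2=O)cc(OC)c1OC` differs from compound 3 by (4-chlorophenyl)carbonyl in place of ethynyl on a saturated chain carbon bound to a sulfur. Compound 1 carries the same (4-chlorophenyl)carbonyl group and gives only a limit, so no step beyond the scatter is expected. The expected step is a number no higher from compound 3 to compound 4 (the limit leaves the size open). Compound 4 is thus estimated at 200000 nM, within 100000 nM to 400000 nM, most likely reported again only as a limit.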

Compound 4, half-maximal inhibitory concentration: 20700 nM
Compound 4: the middle estimate sits 9.7-fold (0.99 log units) above what was measured, and the stated range ends above it.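

In this assay, (4-chlorophenyl)carbonyl on a saturated chain carbon bound to a sulfur gives an at least 9.6-fold lower number from compound 3 to compound 4 (0.98 log units; beyond the scatter). An aromatic ring alone at this place does not account for this, as the change from 2-chlorophenyl gives an at least 9.6-fold lower number from compound 2 to compound 4 (0.98 log units; beyond the scatter). The group does not act alone either, as compound 1 carries it too, and 3,4,5-trimethoxyphenyl in place of propyl on an aromatic carbon gives an at least 9.6-fold lower number from compound 1 to compound 4 (0.98 log units; beyond the scatter).

Which part of the (4-chlorophenyl)carbonyl group matters stays open. The compounds shown do not separate the carbonyl from the chlorine, which an amine in place of that chlorine would begin to test.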